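From compound 2 to compound 3: adding a methoxy

This account rests on a few compounds, and the source may have more. Where it says the series, first, only, none or still open, it means among the compounds named here.

In a functional assay on Jurkat cells (Homo sapiens) for antiproliferative activity, read by MTT assay, with a stated time of 72 h (on this read-out higher numbers stand for weaker inhibition and lower numbers for stronger inhibition), compound 2 `COc1cc(C(=O)c2sc3ccccc3c2Nc2ccccc2)cc(OC)c1OC` gives 1600 nM and compound 1 `COc1cc(C(=O)c2sc3ccccc3c2-c2ccc(SC)cc2)cc(OC)c1OC` gives 1900 nM, so the two cannot be told apart. Compound 3 `COc1ccc(Nc2c(C(=O)c3cc(OC)c(OC)c(OC)c3)sc3ccccc23)cc1` differs from compound 2 by methoxy in place of hydrogen on an aromatic carbon, para to a large group. For the measured compounds named here, the only measured step, a 1.2-fold lower number from compound 1 to compound 2 (0.07 log units; within the scatter), is a different change and offers weak guidance. An estimated 1.8-fold lower number from compound 2 to compound 3 (0.25 log units; within the scatter) reflects a small expected move towards stronger inhibition, with wide uncertainty. Compound 3 is expected near 900 nM, within an estimated range of 150 nM to 3000 nM.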

Compound 3, half-maximal inhibitory concentration: 3500 nM
Compound 3: the middle estimate sits 3.9-fold (0.59 log units) below what was measured; the whole stated range lies below it.
By their numbers in this assay, from the lowest: compounds 2, 1 and 3 (each within the scatter of the next, the first and the last beyond it).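

For the compounds shown here, the change from anilino to (4-methoxyphenyl)amino gives a 2.2-fold higher number from compound 2 to compound 3 (0.34 log units; beyond the scatter) in this assay and is the first step here beyond the scatter, so this ring position, para to a large group, does respond to a substituent. For (4-methoxyphenyl)amino in place of 4-(methylsulfanyl)phenyl, the step is a 1.8-fold higher number from compound 1 to compound 3 (0.27 log units; within the scatter) and the two compounds stay close. Nothing measured here gives a reason for the move towards weaker inhibition.

The compounds shown leave open whether this loss is particular to methoxy, or whether a hydroxyl, an amine or a carboxylic acid at the same place would also weaken inhibition.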